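Notes on the step from compound 3 to compound 4

This account rests on a few compounds, and the source may have more. Where it says the series, first, only, none or still open, it means among the compounds named here.

Compound 1 `CN1CCN(c2ccc(-c3cc4c(N5CCN(C(=O)Nc6ccccc6)CC5)ncnc4s3)cc2)CC1` gives 7090 nM in a functional assay on MDA-MB-436 cells (Homo sapiens) for antiproliferative activity, read by MTT assay, with a stated time of 48 h; on this read-out lower numbers stand for stronger inhibition and higher numbers for weaker inhibition
Compound 2 `CN1CCN(c2ccc(-c3cc4c(N5CCN(C(=O)Nc6ccc(Cl)cc6)CC5)ncnc4s3)cc2)CC1` gives 9270 nM in this assay
Compound 3 `CN1CCN(c2ccc(-c3cc4c(N5CCN(C(=O)Nc6ccc(OC(F)(F)F)cc6)CC5)ncnc4s3)cc2)CC1` gives 6250 nM in this assay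

Compound 3 lies within the scatter of compound 1 and compound 2, so the three carry no order. Compound 4 `CN1CCN(c2ccc(-c3cc4c(N5CCN(C(=O)Nc6cccc(F)c6)CC5)ncnc4s3)cc2)CC1` differs from compound 3 as follows: 3-fluorophenyl in place of 4-(trifluoromethoxy)phenyl on an amide-type nitrogen. The measured changes on this aryl group are all small: a 1.3-fold higher number from compound 1 to compound 2 (0.12 log units; within the scatter), a 1.1-fold lower number from compound 1 to compound 3 (0.05 log units; within the scatter) and a 1.5-fold lower number from compound 2 to compound 3 (0.17 log units; within the scatter), each within the scatter. None of them tests 3-fluorophenyl directly, so this remains an extrapolation. No step beyond the scatter is expected in this assay. The expected change is a 1.1-fold higher number from compound 3 to compound 4 (0.05 log units; within the scatter), with no firm direction. Compound 4 is estimated at 7000 nM, with an expected range of 3500 nM to 14000 nM.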

Compound 4, half-maximal inhibitory concentration: 18300 nM
Compound 4: the middle estimate sits 2.6-fold (0.42 log units) below what was measured, outside the stated range (above it).
By their numbers in this assay, from the lowest: compounds 3, 1, 2 and 4 (each within the scatter of the next, the first and the last beyond it).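

Changes to the aryl group on the amide-type nitrogen are no longer all within the scatter: 3-fluorophenyl gives a 2.9-fold higher number from compound 3 to compound 4 (0.47 log units; beyond the scatter) and a 2.6-fold higher number from compound 1 to compound 4 (0.41 log units; beyond the scatter) in the series. Against 4-chlorophenyl the change is a 2.0-fold higher number from compound 2 to compound 4 (0.30 log units; within the scatter) and leaves compound 2 and compound 4 without an order. Nothing available explains these steps.

Still open, going by these compounds, is whether 4-fluorophenyl would track 3-fluorophenyl or 4-chlorophenyl, which would separate the fluoro group from its ring position. Also open, on these data alone, is how an amine or a carboxylic acid on this aryl group would read.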